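Swapping the methyl ring for a chlorine-bearing ring

This account rests on a few compounds, and the source may have more. Where it says the series, first, only, none or still open, it means among the compounds named here.

Measured compounds:
compound 1, `O=C(NCc1ccc(CNS(=O)(=O)c2ccccc2)cc1)c1cccc(F)c1`: 100 nM
compound 2, `O=C(NCc1ccc(CNS(=O)(=O)c2ccccc2)cc1)c1c(Cl)cc(Cl)cc1Cl`: 10 nM
compound 3, `Cc1cccc(C(=O)NCc2ccc(CNS(=O)(=O)c3ccccc3)cc2)c1`: 1000 nM

In an assay on MDA-MB-231 cells for binding affinity to C-X-C chemokine receptor type 4 (Homo sapiens), read by immunofluorescence and microscopy, with stated times of 10 min and 30 min (on this read-out lower numbers stand for an effect already at smaller amounts and higher numbers for an effect only at larger amounts of compound), compound 3 gives the highest number of the three, with a 10-fold higher number from compound 1 to compound 3 (1.00 log units; beyond the scatter) and a 100-fold higher number from compound 2 to compound 3 (2.00 log units; beyond the scatter) marking its distance from the others. Compound 4, `O=C(NCc1ccc(CNS(=O)(=O)c2ccccc2)cc1)c1ccc(Cl)cc1`, carries the change (4-chlorophenyl in place of 3-methylphenyl on a carbonyl carbon). Among the compounds with values here, two measured steps bear on it: the change from fluoro to methyl, a 10-fold higher number from compound 1 to compound 3 (1.00 log units; beyond the scatter), and the change from the chlorine-rich ring to the methyl ring, a 100-fold higher number from compound 2 to compound 3 (2.00 log units; beyond the scatter), both moving toward higher numbers once methyl arrives. Removing methyl and bringing in chlorine is therefore expected to lower the number in this assay, by about a 10-fold lower number from compound 3 to compound 4 (1.00 log units; beyond the scatter). Compound 4 is estimated at 100 nM, within 20 nM to 500 nM.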

Compound 4, effective concentration (reported as EC, without a stated level of effect): 100 nM
The estimate for compound 4 equals the measured number at the digits printed; low and high end bracket the measured number.
By their numbers in this assay, from the lowest: compound 2; then compounds 1 and 4 (each within the scatter of the next); then compound 3.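

Putting the 4-chlorophenyl ring in place of the 3-methylphenyl ring on the carbonyl carbon lowers the number (a 10-fold lower number from compound 3 to compound 4 (1.00 log units; beyond the scatter)), so a single chlorine on this ring is enough for a clear step. That single chlorine does not reach the level of the 2,4,6-trichlorophenyl ring (a 10-fold higher number from compound 2 to compound 4 (1.00 log units; beyond the scatter)), and the 4-chlorophenyl ring sits level with the 3-fluorophenyl ring (no change at the digits printed from compound 1 to compound 4 (within the scatter)). The compounds shown leave open how an amine or a carboxylic acid on this ring would read. Nothing given here explains these steps.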